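Bromophenyl to trifluoromethylbenzyloxy on the tetrahydronaphthalene arm

The compounds below may be only part of what the source reports. "The series", "measured", "known", "first", "only" and "open" are said of these compounds alone.

Working notes on a small series tested in a functional assay on XF498 cells (Homo sapiens) for inhibition, with a stated time of 72 h; a higher number here means a weaker inhibitor, a lower number a stronger inhibitor. Of the compounds shown here, two have numbers so far. Compound 1 `CCCC1(c2ccccc2)CC(=O)C(C(CC(=O)c2ccc(-c3ccc(Br)cc3)cc2)c2ccccc2)=C(O)O1` carries an open-chain phenyl-propanone arm; in this assay compound 1 reaches only the assay limit of > 10000 nM, which is a limit and not a measured number. For the measured compounds named here, compound 2 `CC1(c2ccccc2)CC(=O)C(C2CC(c3ccc(-c4ccc(Br)cc4)cc3)Cc3ccccc32)=C(O)O1`, with the arm closed into a fused bicyclic system and a shorter chain on the lactone, gives 1360 nM in this assay, the only numerical value in the set. The other entry belongs to compound 1 and is a limit of the assay (the limit of > 10000 nM in this assay, at which 1 of the 2 values shown sits). Going by the values given here, no pair differing in a single place has been measured, so no step size is established.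

Compound 3 `CC1(c2ccccc2)CC(=O)C(C2CC(c3ccc(OCc4ccc(C(F)(F)F)cc4)cc3)Cc3ccccc32)=C(O)O1` is the next candidate. It differs from compound 2 by (4-(trifluoromethyl)benzyl)oxy in place of 4-bromophenyl on an aromatic carbon, in words (4-(trifluoromethyl)benzyl)oxy in place of 4-bromophenyl on an aromatic carbon. Among the compounds with values here, with no comparable step in hand, the expected step from compound 2 to compound 3 is set at a 1.5-fold higher number from compound 2 to compound 3 (0.17 log units; within the scatter), near the scatter, direction undetermined. Compound 3 is therefore estimated at 2000 nM, with a range from 500 nM to 10000 nM.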

Compound 3, half-maximal inhibitory concentration: > 10000 nM
Compound 3 gave a limit, no number; the forecaster's own chance of this, stated with the estimate: 30%; middle value at least 5.0-fold (0.69 log units) from the limit.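

Swapping 4-bromophenyl for (4-(trifluoromethyl)benzyl)oxy on the aromatic carbon gives the first single-place comparison in the series, an at least 7.3-fold higher number from compound 2 to compound 3 (0.86 log units; beyond the scatter) in this assay, which shows that this position does not tolerate every large group equally. The size of the step is only a bound, since compound 3 stands at a limit of the assay and not at a number. Within the series, the read-out at this point is now more often a limit than a measured number: the limit of > 10000 nM in this assay, at which 2 of the 3 values shown sit.

This one pair loses the bromine and brings in the oxygen, the benzyl carbon and the trifluoromethyl all at once, and which of these goes with the higher number cannot be read from it. Also open, going by these compounds, is how a plain benzyloxy, a methoxy, an amine or a carboxylic acid on the same aromatic carbon would read, and whether any group at this place can improve on the 4-bromophenyl of compound 2.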